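Chloro to methoxy on the way to compound 3

This account rests on a few compounds, and the source may have more. Where it says the series, first, only, none or still open, it means among the compounds named here.

Measured in a functional assay on A549 cells (Homo sapiens) for antiproliferative activity, read by MTT assay, with a stated time of 72 h; a lower number here means a stronger inhibitor, a higher number a weaker inhibitor:
Compound 1 `NC1=NC2(CCSCC2)N(OCCCOc2cccc(Cl)c2)C(N)=N1`: 60 nM
Compound 2 `NC1=NC2(CCSCC2)N(OCCCOc2ccc(Cl)cc2)C(N)=N1`: 580 nM

Compound 2, at 580 nM, is the weaker of the two measured compounds in this assay. Compound 3 `COc1ccc(OCCCON2C(N)=NC(N)=NC23CCSCC3)cc1` differs from it in one place, with methoxy in place of chloro on an aromatic carbon, para to a large group (methoxy in place of chloro on an aromatic carbon). Among the compounds with values here, only one measured step bears on this change, and only indirectly: a 9.7-fold higher number from compound 1 to compound 2 (0.99 log units; beyond the scatter), with 4-chlorophenyl in place of 3-chlorophenyl. Within the data shown here, it shows that the number can respond to a change on this ring, but no measured step replaces chloro with another group, so it gives no direction for methoxy. No step beyond the scatter is therefore expected, although the range is kept wide. The expected change is a 1.2-fold higher number from compound 2 to compound 3 (0.08 log units; within the scatter). For compound 3, the estimated value is 700 nM, with an expected range of 200 nM to 2400 nM.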

Compound 3, half-maximal inhibitory concentration: 240 nM
Estimate against measurement, compound 3: 2.9-fold (0.46 log units) above; the range from low to high includes it.
By their numbers in this assay, from the lowest: compound 1; then compound 3; then compound 2.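

In this assay, the group para to a large group now has a second measured form, and methoxy in place of chloro gives a 2.4-fold lower number from compound 2 to compound 3 (0.38 log units; beyond the scatter). Within the data shown here, this is the first sign that the identity of the group at this place, and not only its place on the ring, moves the number. The change recovers only part of what the move of chloro had cost, since there remains a 4.0-fold higher number from compound 1 to compound 3 (0.60 log units; beyond the scatter) and the 3-chlorophenyl compound keeps the lowest number of the three. No accompanying measurement offers an explanation for this step.

The compounds shown leave open whether methoxy would act the same way in place of chloro on the ring of compound 1. They also leave open how an amine or a carboxylic acid at the place para to a large group would change the number.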